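Replacing a Ring by an Alkenyl Chain on the Core

This account rests on a few compounds, and the source may have more. Where it says the series, first, only, none or still open, it means among the compounds named here.

Compound 3 `COc1cc(Cc2nc3c(N)ncnc3n2CC2CCCO2)cc(OC)c1OC` gives 91200 nM in a functional assay on MCF7 cells (Homo sapiens) for antiproliferative activity (on this read-out higher numbers stand for weaker inhibition and lower numbers for stronger inhibition), the highest of the three numbers shown; compound 1 `CCCn1c(Cc2cc(OC)c(OC)c(OC)c2)nc2c(N)ncnc21` gives 46800 nM and compound 2 `CCCCn1c(Cc2cc(OC)c(OC)c(OC)c2)nc2c(N)nc(F)nc21` gives 24000 nM. Compound 4 `CC/C=C\Cn1c(Cc2cc(OC)c(OC)c(OC)c2)nc2c(N)ncnc21` differs from compound 3 by but-1-en-1-yl in place of oxolan-2-yl on a saturated chain carbon bound to an aromatic nitrogen. For the measured compounds named here, the only measured step touching this position is a 1.9-fold higher number from compound 1 to compound 3 (0.29 log units; within the scatter), where the oxolan-2-yl ring made little difference. Going by the values given here, no measured compound carries an alkenyl chain, so removing the ring can only be read as a return toward the region of compound 1, and no step beyond the scatter is expected in this assay. Compound 4 is therefore expected to give 50000 nM (range 15000 nM to 160000 nM), an estimated step of a 1.8-fold lower number from compound 3 to compound 4 (0.26 log units; within the scatter).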

Compound 4, half-maximal inhibitory concentration: 64600 nM
Estimate against measurement, compound 4: 1.3-fold (0.11 log units) below; low and high end bracket the measured number.
By their numbers in this assay, from the lowest: compounds 2, 1, 4 and 3 (each within the scatter of the next, the first and the last beyond it).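

In this assay, the open chain replaces the ring with a 1.4-fold lower number from compound 3 to compound 4 (0.15 log units; within the scatter) and replaces ethyl with a 1.4-fold higher number from compound 1 to compound 4 (0.14 log units; within the scatter) as the group on a saturated chain carbon bound to an aromatic nitrogen. Oxolan-2-yl, ethyl and but-1-en-1-yl in this place therefore stay within the usual scatter of one another, so neither the ring nor the double bond separates these compounds on this read-out. No measured evidence bears on the reason for this result. As far as these compounds go, whether an amine or a carboxylic acid in this place would move the number beyond the scatter remains open.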